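A few compounds are considered here, and "the series" means these few. Any claim that something is new, unique, unknown or untested is made for them only; others in the source may bear on it.

Measured in a physicochemical assay for lipophilicity; on this read-out lower numbers stand for lower lipophilicity and higher numbers for higher lipophilicity:
- compound 1, `CC(/C=C/CC(C)CCCC(C)C)=C\C(=O)OCC(C)C`: 7.69
- compound 2, `CC(/C=C/CC(C)CCCC(C)C)=C\C(=O)Oc1ccccc1`: 7.67
- compound 3, `CC(/C=C/CC(C)CCCC(C)C)=C\C(=O)O`: 5.95

Compound 3 stands lowest of the three numbers. The steps of a number 1.74 log units lower from compound 1 to compound 3 (beyond the scatter) and a number 1.72 log units lower from compound 2 to compound 3 (beyond the scatter) are both large, while a number 0.02 log units lower from compound 1 to compound 2 (within the scatter) is within the scatter. Compound 4, `CC(/C=C/CC(C)CCCC(C)C)=C\C(=O)N(C)C`, has not yet been measured. It differs from compound 3 in one place: dimethylamino in place of hydroxy on a carbonyl carbon.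

Among the compounds with values here, none of the measured steps covers this change directly; both large steps concern replacing a group on the oxygen with hydrogen, whereas here the hydroxy itself leaves and dimethylamino enters on the carbonyl carbon. The measured steps therefore only show that compound 3 sits well below the two esters and give no direct guide to the dimethylamino analogue. An amide of this kind is expected to stay in the region of compound 3 rather than to return toward compound 1 or compound 2, so compound 4 is expected at 5.5, with a range from 4.7 to 6.3. The expected step is a number 0.45 log units lower from compound 3 to compound 4 (beyond the scatter), and it may well fall within the scatter.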

Compound 4, partition coefficient: 4.94
The estimate for compound 4 lay 0.56 log units above the measured number, within the range that was stated.
By their numbers in this assay, from the lowest: compound 4; then compound 3; then compounds 2 and 1 (each within the scatter of the next).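

In this assay, the position on the carbonyl carbon proves able to go lower than the acid, which had been the bottom of the series: the carboxy to dimethylcarbamoyl change gives a further large move (a number 1.01 log units lower from compound 3 to compound 4 (beyond the scatter)). Within the data shown here, compound 4 also lies far from both esters (a number 2.73 log units lower from compound 2 to compound 4 (beyond the scatter); a number 2.75 log units lower from compound 1 to compound 4 (beyond the scatter)), so what is attached through this carbonyl carbon spans a wider range than the earlier compounds showed. Nothing available accounts for these steps.

As far as these compounds go, it remains open where an amino, a methylamino or a morpholine group on the same carbonyl carbon would fall, and so whether this position follows the dimethylamino group alone. The compounds shown also leave open whether the step from hydroxy to dimethylamino would keep its size on a shorter chain.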